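The compounds below may be only part of what the source reports. "The series", "measured", "known", "first", "only" and "open" are said of these compounds alone.

Working notes on the series.

Compound 1 is `O=C(/C=C/C(=O)N1C/C(=C\c2ccccc2)C(=O)/C(=C/c2ccccc2)C1)Nc1ccc(Cl)c(Cl)c1` and compound 2 is `CC(=O)c1ccc(NC(=O)/C=C/C(=O)N2C/C(=C\c3ccccc3)C(=O)/C(=C/c3ccccc3)C2)cc1`; both carry the same core and differ only in the aryl group on the amide-type nitrogen. In a functional assay on Molt4/C8 cells (Homo sapiens) for cytotoxicity (on this read-out lower numbers stand for stronger inhibition and higher numbers for weaker inhibition), compound 1 gives 1700 nM. In this assay, among the compounds with values here, compound 2 gives 1400 nM, which is the lower of the two numbers so far, though the gap to compound 1 is within the scatter, so no order between the two can be read from it. Within the data shown here, the one measured step, a 1.2-fold lower number from compound 1 to compound 2 (0.08 log units; within the scatter), exchanges the whole aryl group and stays within the scatter.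

Compound 3 is `Cc1ccc(NC(=O)/C=C/C(=O)N2C/C(=C\c3ccccc3)C(=O)/C(=C/c3ccccc3)C2)cc1`. It differs from compound 2 by methyl in place of acetyl on an aromatic carbon. Among the measured compounds shown here, the single measured step bears on this change, since it also altered only the substituent pattern on this aryl group, and it produced no movement beyond the scatter. Nothing in the two numbers points to a larger effect for the smaller substituent. For compound 3 the expected result in this assay is therefore 1500 nM, with a range from 700 nM to 3500 nM. The expected step of a 1.1-fold higher number from compound 2 to compound 3 (0.03 log units; within the scatter) is estimated to fall within the scatter.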

Compound 3, half-maximal inhibitory concentration: 660 nM
The estimate for compound 3 lay 2.3-fold (0.36 log units) above the measured number; the whole stated range lies above it.
By their numbers in this assay, from the lowest: compound 3; then compounds 2 and 1 (each within the scatter of the next).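

In this assay, within the data shown here, the aryl group on the amide-type nitrogen can move the number beyond the scatter, which the first step between compound 1 and compound 2 did not show: methyl in place of acetyl on an aromatic carbon, para to a large group, gives a 2.1-fold lower number from compound 2 to compound 3 (0.33 log units; beyond the scatter) and is modest in size. The 4-methylphenyl group also separates from the 3,4-dichlorophenyl group, with a 2.6-fold lower number from compound 1 to compound 3 (0.41 log units; beyond the scatter) as a second modest step, so compound 3 holds the lowest number of the three and the order at this aryl group is set by what sits on it, not by the mere presence of a substituent. Nothing on hand says why methyl goes with the lower number here.

Whether the change belongs to methyl itself or to the loss of acetyl stays open, as the three compounds shown offer only three aryl groups and no unsubstituted phenyl. From the compounds shown here alone, how a methoxy group, an amine or a carboxylic acid would read at this same place, and whether a longer chain than methyl keeps the lower number, also stays open.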